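The source may hold more compounds than are shown below. What is called first, only, known or untested is meant among the compounds shown, and "the series" means these compounds.

Three compounds share one core, and a functional assay on B16-F10 cells (Mus musculus) for inhibition, read by MTT assay, with a stated time of 72 h (on this read-out lower numbers stand for stronger inhibition of growth and higher numbers for weaker inhibition of growth), gives a number for each. Compound 1 `CC(C)=CC(=O)NC(=N)NC(=O)C=C(C)C` gives 21300 nM. Compound 2 `CC(C)=CCC/C(C)=C/C(=O)NC(=N)NC(=O)C=C(C)C` gives 25000 nM, the highest of the three numbers shown, though its gaps to compound 1 and compound 3 are both within the scatter, so no order among them can be claimed. Compound 3 `CC(C)=CCC/C(C)=C/C(=O)NC(=N)N` gives 17100 nM. The two single-point steps were a 1.2-fold higher number from compound 1 to compound 2 (0.07 log units; within the scatter) and a 1.5-fold lower number from compound 2 to compound 3 (0.16 log units; within the scatter).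

Compound 4 `CC(C)=CCC/C(C)=C/CC/C(C)=C/C(=O)NC(=N)NC(=O)/C=C(\C)CCC=C(C)C` is not yet measured. It differs from compound 2 in one place: 3,7-dimethylocta-2,6-dien-1-yl in place of hydrogen on a saturated chain carbon bound to a double-bonded chain carbon. The step from compound 1 to compound 2 bears on this directly, since it also placed a chain on a saturated chain carbon bound to a double-bonded chain carbon, and it was a 1.2-fold higher number from compound 1 to compound 2 (0.07 log units; within the scatter), within the scatter. A longer chain of the same kind is therefore expected to move the number little, in no settled direction. The expected step is no change at the digits printed from compound 2 to compound 4 (within the scatter). For compound 4 the estimate in this assay is 25000 nM, within a range of 12000 nM to 50000 nM.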

Compound 4, concentration for 50% growth inhibition: 18900 nM
Compound 4: the middle estimate sits 1.3-fold (0.12 log units) above what was measured; the range from low to high includes it.
By their numbers in this assay, from the lowest: compounds 3, 4, 1 and 2 (each within the scatter of the next).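

In this assay, placing 3,7-dimethylocta-2,6-dien-1-yl, with its 10 carbon atoms and 2 double bonds, on a saturated chain carbon bound to a double-bonded chain carbon gave a 1.3-fold lower number from compound 2 to compound 4 (0.12 log units; within the scatter) at this place. The earlier step, a 1.2-fold higher number from compound 1 to compound 2 (0.07 log units; within the scatter), covered only the shorter 3-methylbut-2-en-1-yl chain, so the new result extends the finding: neither chain shifts the number beyond the scatter. Nothing available explains this result.

Both chains shown consist only of carbon and hydrogen, so it remains open whether an amine or a carboxylic acid at this same place would separate from these numbers. From the compounds shown here alone, it is equally open whether a still longer chain of the same kind would do so.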